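Trifluoromethyl on the aromatic ring of compound 2

This account rests on a few compounds, and the source may have more. Where it says the series, first, only, none or still open, it means among the compounds named here.

Three compounds share the core here: compound 1 (`CC1(COCc2ccc(OC(F)(F)F)cc2)Cn2cc([N+](=O)[O-])nc2O1`), compound 2 (`CC1(COc2ccccc2)Cn2cc([N+](=O)[O-])nc2O1`) and compound 3 (`CC1(COc2ccc(C(F)(F)F)cc2)Cn2cc([N+](=O)[O-])nc2O1`). In an ADME assay on MRC5 cells (Homo sapiens) for cytotoxicity, read by fluorescence, with a stated time of 72 h (a higher number here means a weaker inhibitor, a lower number a stronger inhibitor), compound 1 gives 60000 nM as a measured number. Compound 2 stands at > 64000 nM in this assay and this is a limit, not a number.

Compound 3 follows from compound 2 through the change trifluoromethyl in place of hydrogen on an aromatic carbon with trifluoromethyl in place of hydrogen on an aromatic carbon, para to a large group. For the measured compounds named here, no pair of measured compounds differs in one place only, so the series offers no direct precedent for this change. In this assay the expectation is for no step beyond the scatter, with any drift toward lower numbers. Going by the values given here, the only measured number so far is that of compound 1 at 60000 nM and it gives no reason to expect a large move. Expressed as a change, the expected move is an at least 1.1-fold lower number from compound 2 to compound 3 (0.06 log units; that floor lies within the scatter) and it is estimated to stay small. For compound 3 the estimated value is 55000 nM with an expected range from 28000 nM to 64000 nM and a report as a limit is somewhat more likely than a number.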

Compound 3, half-maximal inhibitory concentration: > 64000 nM
Compound 3: no number, only a limit; the forecaster's own chance of this, stated with the estimate: 60%; middle value at least 1.1-fold (0.06 log units) away from the limit.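

In this assay, no step can be read between compound 2 and compound 3, because both stand at the same limit and not at a number: the limit of > 64000 nM in this assay, at which 2 of the 3 values shown sit.

On these data alone, whether trifluoromethyl in place of hydrogen on an aromatic carbon shifts the read-out in this assay in either direction stays open: neither compound 2 nor compound 3 carries a measured number.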